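The source may report more compounds than this note shows. Statements on the series, on what has been measured and on what is new or still open speak of the compounds shown alone.

Measured so far in a functional assay (spleen, spleen) for activation, with Mus musculus as the target; a lower number here means that less compound is needed, a higher number that more compound is needed for the effect:
compound 1 `CCOc1nc(N)c2nc(O)n(Cc3ccccc3)c2n1`: 0.1 uM
compound 2 `Nc1ncnc2c1nc(O)n2Cc1cccc2ccccc12`: 10 uM
compound 3 `Nc1ncnc2c1nc(O)n2Cc1ccc(F)cc1`: 10 uM

Compound 1 holds the lowest of the three numbers. In this assay compound 1 gives 0.1 uM, while compound 2 gives 10 uM and compound 3 gives 10 uM; both of those gaps from compound 1 lie well beyond the scatter. Going by the values given here, no pair of these three differs in only one place, so no single-point step is available, and the two higher numbers belong to compounds that differ from compound 1 in more than one respect.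

Compound 4 `CCCC[S+]([O-])c1nc(N)c2nc(O)n(Cc3ccccc3)c2n1` is the next point to measure. It differs from compound 1 in one place: a group of 6 heavy atoms (4 carbon, 1 oxygen, 1 sulfur; no ring) in place of a group of 3 heavy atoms (2 carbon, 1 oxygen; no ring), on an aromatic carbon. The new group is larger and carries the sulfur-oxygen unit in place of the ethoxy oxygen, at the position between two ring nitrogen atoms. Nothing measured here tests that position directly. The step of a 3.0-fold higher number from compound 1 to compound 4 (0.48 log units; beyond the scatter) is expected to be a small rise, close to the edge of the scatter. Compound 4 is therefore estimated at 0.3 uM, in the range 0.05 uM to 3 uM.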

Compound 4, minimum effective concentration: 0.01 uM
Compound 4: the middle estimate sits 30-fold (1.48 log units) above what was measured; measured number outside the range, below it.
By their numbers in this assay, from the lowest: compound 4; then compound 1; then compounds 2 and 3 (each within the scatter of the next).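

In this assay, replacing ethoxy with the group of 6 heavy atoms carrying the sulfur-oxygen unit gives a 10-fold lower number from compound 1 to compound 4 (1.00 log units; beyond the scatter). Going by these compounds alone, this is the first single-place step, and it shows that the position between two ring nitrogen atoms tolerates a larger group on the shared core, with the number falling rather than rising. No supporting data on this change are available, so the drop stays unexplained.

The sulfur-oxygen unit and the longer chain enter together in this one step, so their separate shares cannot be read. A butoxy group at this position would test the chain with the ethoxy-type oxygen kept, while an ethyl chain on the same sulfur-oxygen unit would test the unit with the shorter chain.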